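The source may hold more compounds than are shown below. What is called first, only, known or untested is meant among the compounds shown, and "the series" means these compounds.

Measured compounds:
- compound 1 `COc1ccc(-c2nnc(NC(=O)/C=C/c3ccc(F)cc3)s2)cc1`: 0.75 ug/mL
- compound 2 `O=C(/C=C/c1ccc(C(F)(F)F)cc1)Nc1nnc(-c2ccc(Cl)cc2)s1`: 3.09 ug/mL
- compound 3 `O=C(/C=C/c1ccc(F)cc1)Nc1nnc(-c2ccc(Cl)cc2)s1`: 2.06 ug/mL

In a functional assay on A549 cells (Homo sapiens) for antiproliferative activity, read by MTT assay, with a stated time of 48 h (a higher number here means a weaker inhibitor, a lower number a stronger inhibitor), compound 2 gives the highest of the three numbers. The step of a 1.5-fold lower number from compound 2 to compound 3 (0.18 log units; within the scatter) is within the scatter, so compound 2 and compound 3 are not separated. For the measured compounds named here, the step of a 2.7-fold lower number from compound 3 to compound 1 (0.44 log units; beyond the scatter) is the one change that is clearly read: methoxy in place of chloro on an aromatic carbon.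

Compound 4 `COc1ccc(-c2nnc(NC(=O)/C=C/c3ccc(C(F)(F)F)cc3)s2)cc1` is unmeasured. It differs from compound 2 by methoxy in place of chloro on an aromatic carbon, the same change as from compound 3 to compound 1, at the same place. The cores of compound 2 and compound 3 differ by trifluoromethyl in place of fluoro on an aromatic carbon. Because a 2.7-fold lower number from compound 3 to compound 1 (0.44 log units; beyond the scatter) was seen once on the neighbouring core, a step of similar size, a 2.6-fold lower number from compound 2 to compound 4 (0.41 log units; beyond the scatter), is expected for compound 4 in this assay. Compound 4 is thus estimated at 1.2 ug/mL, with a likely range from 0.6 ug/mL to 2.5 ug/mL.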

Compound 4, half-maximal inhibitory concentration: 0.69 ug/mL
The estimate for compound 4 lay 1.7-fold (0.24 log units) above the measured number; measured number inside the range.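

In this assay, methoxy in place of chloro carries over to the trifluoromethyl core, with a 4.5-fold lower number from compound 2 to compound 4 (0.65 log units; beyond the scatter), and the two cores give steps of matching size: the same change on two cores in this assay, a 2.7-fold lower number (0.44 log units; beyond the scatter) from compound 3 to compound 1 and a 4.5-fold lower number (0.65 log units; beyond the scatter) from compound 2 to compound 4, 1.6-fold (0.21 log units) apart, within the scatter of two such steps. Trifluoromethyl in place of fluoro separates nothing on the methoxy core, with a 1.1-fold lower number from compound 1 to compound 4 (0.04 log units; within the scatter), which agrees with the chloro core: the same change on two cores in this assay, a 1.5-fold lower number (0.18 log units; within the scatter) from compound 2 to compound 3 and a 1.1-fold higher number (0.04 log units; within the scatter) from compound 4 to compound 1, 1.6-fold (0.21 log units) apart, within the scatter of two such steps. These results rest on one pair of cores and a single cell assay, so they show transfer between these cores only, not a general rule for the series, and they give no cause for either step.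

Still open, going by these compounds, is whether an amine, a hydroxyl or a longer alkoxy chain in place of methoxy would follow the same course. A carboxylic acid in place of trifluoromethyl is equally untested by the compounds shown here.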